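A Halogen Swap on the Benzyl Group of Compound 2

This account rests on a few compounds, and the source may have more. Where it says the series, first, only, none or still open, it means among the compounds named here.

Going by the values given here, in a functional assay on Bel7402/5-FU cells (Homo sapiens) for antiproliferative activity, read by MTT assay, with a stated time of 72 h (on this read-out higher numbers stand for weaker inhibition and lower numbers for stronger inhibition), compound 2 `C=C1C(=O)O[C@H]2[C@H]1CC/C(COC(=O)Cn1cc(F)c(=O)n(Cc3ccc(Cl)cc3)c1=O)=C\CC[C@@]1(C)O[C@@H]21` gives 2420 nM, the lower of the two numbers known so far, though compound 1 `C=C1C(=O)O[C@H]2[C@H]1CC/C(Cn1cc(Cn3cc(F)c(=O)n(Cc4ccc(F)cc4)c3=O)nn1)=C\CC[C@@]1(C)O[C@@H]21` gives 4860 nM, which lies within the scatter of that figure. Compound 3 `C=C1C(=O)O[C@H]2[C@H]1CC/C(COC(=O)Cn1cc(F)c(=O)n(Cc3ccc(F)c(F)c3)c1=O)=C\CC[C@@]1(C)O[C@@H]21` differs from compound 2 in a single place: 3,4-difluorophenyl in place of 4-chlorophenyl on a saturated chain carbon bound to an aromatic nitrogen. Among the compounds with values here, no pair of measured compounds shows such a change, so the step of a 1.2-fold higher number from compound 2 to compound 3 (0.09 log units; within the scatter) is expected to be small, not beyond the scatter, in no certain direction. Compound 3 is therefore estimated at 3000 nM in this assay, with a range from 1200 nM to 7500 nM.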

Compound 3, half-maximal inhibitory concentration: 4480 nM
For compound 3 the middle estimate is 1.5-fold (0.17 log units) below the measured one, within the range that was stated.
By their numbers in this assay, from the lowest: compounds 2, 3 and 1 (each within the scatter of the next).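

In this assay, 3,4-difluorophenyl in place of 4-chlorophenyl on a saturated chain carbon bound to an aromatic nitrogen gives a 1.9-fold higher number from compound 2 to compound 3 (0.27 log units; within the scatter). This position therefore now has a step of its own, and the two halogen-bearing aryl groups cannot be told apart by this read-out. Nothing available bears on what lies behind this result. 

Going by these compounds, it remains open whether an unsubstituted phenyl, or a phenyl carrying an amine or a carboxylic acid, would give a step beyond the scatter. On these data alone, whether a longer chain between the aromatic nitrogen and the aryl ring would do so is equally open.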